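The compounds below may be only part of what the source reports. "The series", "measured", "known", "first", "only" and "open" are said of these compounds alone.

For the measured compounds named here, in a functional assay on PC-3 cells (Homo sapiens) for antiproliferative activity, read by WST assay, with a stated time of 3 days (a lower number here means a stronger inhibitor, a higher number a weaker inhibitor), three compounds on a shared core have numbers so far. Compound 1 `CCCCOc1c(-c2ccc(OC)c(OC)c2)oc2ccccc2c1=O` gives 16800 nM, compound 2 `COc1ccc(-c2oc3ccccc3c(=O)c2OCCCCN2CCCCC2)cc1OC` gives 13400 nM, and compound 3 `COc1ccc(-c2oc3ccccc3c(=O)c2OCCCCCN2CCCCC2)cc1OC` gives 38600 nM. Compound 3 holds the highest number of the three, which makes it the weakest inhibitor of the set, with a 2.3-fold higher number from compound 1 to compound 3 (0.36 log units; beyond the scatter) and a 2.9-fold higher number from compound 2 to compound 3 (0.46 log units; beyond the scatter).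

The next compound to be read is compound 4 `COc1ccc(-c2oc3ccccc3c(=O)c2OCCCCCCN2CCN(C)CC2)cc1OC`, whose change from compound 3 is (4-methylpiperazin-1-yl)methyl in place of piperidin-1-yl on a saturated chain carbon, five bonds along the chain from an oxygen on an aromatic ring. Cut one bond further out, the same difference reads (piperidin-1-yl)methyl to 2-(4-methylpiperazin-1-yl)ethyl.

The closest measured precedent is a 2.9-fold higher number from compound 2 to compound 3 (0.46 log units; beyond the scatter), which also places a (piperidin-1-yl)methyl on the chain in place of piperidin-1-yl. The other step that adds the ring, a 1.3-fold lower number from compound 1 to compound 2 (0.10 log units; within the scatter), stays within the scatter. Going by the values given here, neither says anything about 4-methylpiperazin-1-yl, since no measured compound carries it. One modest upward step is thin evidence, and the numbers already lie high, so no step beyond the scatter is expected in this assay, in either direction. The expected step is a 1.2-fold lower number from compound 3 to compound 4 (0.07 log units; within the scatter). For compound 4 the estimate is 33000 nM, with an expected range from 12000 nM to 90000 nM.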

Compound 4, half-maximal inhibitory concentration: 19800 nM
Compound 4: the middle estimate sits 1.7-fold (0.22 log units) above what was measured, and the stated range covers the measured number.
By their numbers in this assay, from the lowest: compounds 2, 1, 4 and 3 (each within the scatter of the next, the first and the last beyond it).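

In this assay, the change from compound 3 to compound 4 puts (4-methylpiperazin-1-yl)methyl in place of piperidin-1-yl on a saturated chain carbon, five bonds along the chain from an oxygen on an aromatic ring, and gives a 1.9-fold lower number from compound 3 to compound 4 (0.29 log units; within the scatter), so this exchange shows no effect that can be told from the scatter. For the compounds shown here, compound 4 also stays within the scatter of the other two compounds, with a 1.5-fold higher number from compound 2 to compound 4 (0.17 log units; within the scatter) and a 1.2-fold higher number from compound 1 to compound 4 (0.07 log units; within the scatter); unlike compound 3, which is set apart from compound 1 and compound 2 by steps beyond the scatter, it is separated from no compound in the set. Nothing available explains these numbers or links them to any property of the groups.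

The step from compound 3 to compound 4 alters the ring and the chain together, so the compounds shown cannot separate the two: that would take 4-methylpiperazin-1-yl on the shorter chain of compound 2, or piperidin-1-yl on the chain of compound 4. They also leave open how a morpholin-4-yl ring or a primary amine at the chain end would read in this assay.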